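A few compounds are considered here, and "the series" means these few. Any claim that something is new, unique, unknown or untested is made for them only; others in the source may bear on it.

Of the compounds shown here, three have so far been measured in an assay on isolated protein for inhibition of Neprilysin (Oryctolagus cuniculus); on this read-out higher numbers stand for weaker inhibition and lower numbers for stronger inhibition. Compound 1 `O=C(N[C@H](CSCc1ccccc1)C(=O)O)[C@@H](CS)Cc1ccccc1` gives 14 nM; 9 nM (2 entries) over repeated runs, as shown by the several entries of compound 1 in this assay, 14 nM; 9 nM (2 entries). Compound 2 `O=C(N[C@@H](CSCc1ccccc1)C(=O)O)[C@@H](CS)Cc1ccccc1` gives 19 nM, the highest of the two single numbers recorded. Compound 3 `CCSC[C@@H](NC(=O)[C@@H](CS)Cc1ccccc1)C(=O)O` gives 2.4 nM, and the gap between compound 2 and compound 3 lies beyond the usual scatter, whereas the entries of compound 1 and the number of compound 2 fall within it, which is notable given (the fact that compounds 1 and 2 differ only in the configuration as drawn).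

Compound 4 `O=C(N[C@H](CSCc1ccccc1)C(=O)O)[C@H](CS)Cc1ccccc1` has not yet been measured. Compared with compound 2, (the two compounds have the same atoms and bonds and differ only in configuration as drawn: 2 of 2 stereo elements differ (all stereocentres are inverted: mirror images); a stereocentre at a saturated chain carbon is drawn R in compound 2 and S in compound 4; a stereocentre at a saturated chain carbon is drawn S in compound 2 and R in compound 4). Within the data shown here, no measured pair of mirror images is available to set the size of such a change. Since a single inverted centre left the numbers of compound 1 and compound 2 within the scatter, the step from compound 2 to compound 4 is expected to be small and toward weaker inhibition, at a 1.8-fold higher number from compound 2 to compound 4 (0.27 log units; within the scatter). Compound 4 is therefore estimated at 35 nM, within a range from 8 nM to 200 nM.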

Compound 4, half-maximal inhibitory concentration: 32 nM
For compound 4 the middle estimate is 1.1-fold (0.04 log units) above the measured one, within the range that was stated.
By their numbers in this assay, from the lowest: compound 3; then compounds 2 and 4 (each within the scatter of the next).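

In this assay, inverting both stereocentres together gives a 1.7-fold higher number from compound 2 to compound 4 (0.23 log units; within the scatter), and configuration is the only thing that can account for this step: the fact that compounds 2 and 4 differ only in the configuration as drawn

Among these compounds, the earlier compounds covered only a single inverted centre, between compound 1 and compound 2, whereas this pair is the first full mirror-image pair. Even this complete inversion leaves the two numbers indistinguishable, so for this pair the read-out does not separate the two arrangements of the stereocentres.

As far as these compounds go, it remains open whether configuration matters as little when the sulfur carries the ethyl group of compound 3 rather than the group shared by compound 2 and compound 4. Also unanswered is whether the same holds when a hydroxamic acid replaces the free thiol.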